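This account rests on a few compounds, and the source may have more. Where it says the series, first, only, none or still open, it means among the compounds named here.

Measured so far in a functional assay on HepG2 cells (Homo sapiens) for inhibition, read by MTT assay; a higher number here means a weaker inhibitor, a lower number a stronger inhibitor:

- Compound 1 `COc1cc2ncnc(Nc3ccc(NC(=O)c4ccc(F)cc4)cc3)c2cc1OC`: 15000 nM
- Compound 2 `COc1cc2ncnc(Nc3ccc(NC(=O)c4cccc(C(F)(F)F)c4)cc3)c2cc1OC`: 83000 nM
- Compound 3 `COc1cc2ncnc(Nc3ccc(NC(=O)c4ccc(C(F)(F)F)cc4)cc3)c2cc1OC`: > 100000 nM

Compound 3 stands at the limit of > 100000 nM in this assay, at which 1 of the 3 values shown sits, which is a limit and not a number. The next compound, compound 4 `COc1cc2ncnc(Nc3ccc(NC(=O)c4ccc(Cl)c(Cl)c4)cc3)c2cc1OC`, carries 3,4-dichlorophenyl in place of 4-(trifluoromethyl)phenyl on a carbonyl carbon.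

All three measured steps change only the group on that carbonyl carbon. Two are modest and beyond the scatter: a 5.5-fold higher number from compound 1 to compound 2 (0.74 log units; beyond the scatter) and an at least 6.6-fold higher number from compound 1 to compound 3 (0.82 log units; beyond the scatter). The third is an at least 1.2-fold higher number from compound 2 to compound 3 (0.08 log units; that floor lies within the scatter), and its floor lies within the scatter. Among the measured compounds shown here, no compound with chlorine has been measured yet, so these steps offer only a rough guide. Compound 1, at 15000 nM, shows that a change of this group can give a measurable number in this assay. A modest move toward a lower number is therefore expected, though compound 4 may also stay at the limit. The expected change is an at least 2.5-fold lower number from compound 3 to compound 4 (0.39 log units; beyond the scatter). For compound 4 the estimated value is 40000 nM, within an expected range of 12000 nM to 100000 nM.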

Compound 4, half-maximal inhibitory concentration: 28000 nM
Estimate against measurement, compound 4: 1.4-fold (0.15 log units) above; the measured number falls inside the stated range.
By their numbers in this assay, from the lowest: compounds 1 and 4 (each within the scatter of the next); then compound 2. At a limit, above all of these: compound 3.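

Swapping either trifluoromethyl-bearing phenyl group on this carbonyl carbon for 3,4-dichlorophenyl lowers the number in this assay, with an at least 3.5-fold lower number from compound 3 to compound 4 (0.55 log units; beyond the scatter) and a 3.0-fold lower number from compound 2 to compound 4 (0.47 log units; beyond the scatter), so a group carrying chlorine brings this series back toward the level of the fluoro compound. Against 4-fluorophenyl, the same group gives a 1.9-fold higher number from compound 1 to compound 4 (0.27 log units; within the scatter), so no order can be set between these two groups. The first of these steps rests on a limit, not a number: the limit of > 100000 nM in this assay, at which 1 of the 4 values shown sits.

Every group shown on this carbonyl carbon is a phenyl ring carrying fluorine or chlorine, so it stays open how a ring carrying an amine, a carboxylic acid or a methoxy group would read in this assay. Going by these compounds, whether a single chlorine on the ring would give a similar number also remains open.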